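This account rests on a few compounds, and the source may have more. Where it says the series, first, only, none or still open, it means among the compounds named here.

Compound 1 `Fc1cccc(F)c1C#Cc1cnc2ccccc2c1` and compound 2 `Fc1cccc(F)c1C#Cc1ccnc2ccccc12` share the same atoms joined differently; the difference between the two cores is not broken down here. In a functional assay on LS174T cells (Homo sapiens) for inhibition, with a stated time of 4 days, tested at 10 uM (a lower number here means a weaker effect, a higher number a stronger effect of the compound at the concentration tested), compound 1 gives 90.4%, whereas compound 2 gives 59%. Compound 3 `Fc1cccc(F)c1C#Cc1cnc2ccccc2c1Cl` carries chloro in place of hydrogen on an aromatic carbon on the core of compound 1, and in this assay compound 3 gives 80.4%, so that a number 10 percentage points lower from compound 1 to compound 3 (within the scatter).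

Compound 4 `Fc1cccc(F)c1C#Cc1ccnc2cc(Cl)ccc12` is built on the core of compound 2 with chloro in place of hydrogen on an aromatic carbon. This is the same kind of change as that from compound 1 to compound 3, not the same: there the place was a six-membered aromatic ring with one nitrogen, ortho to a fused ring, ortho to a large group and opposite the ring nitrogen, while here it is a six-membered aromatic ring of carbon only, meta and para to a fused ring. Among the measured compounds shown here, since the only comparable step is a number 10 percentage points lower from compound 1 to compound 3 (within the scatter), the step from compound 2 to compound 4 is expected to be small, a number 5 percentage points lower from compound 2 to compound 4 (within the scatter). In this assay compound 4 is therefore estimated at 54%, most likely between 35% and 73%.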

Compound 4, a percentage reported as inhibition, at one concentration (the size of the read-out at that concentration, not a potency): 74.3%
Estimate against measurement, compound 4: 20.3 percentage points below; measured number above the stated range.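

In this assay, chloro in place of hydrogen on an aromatic carbon goes with a number 15.3 percentage points higher from compound 2 to compound 4 (beyond the scatter), and this does not repeat what the same kind of change did on the core of compound 1: the same change on two cores in this assay, a number 10 percentage points lower (within the scatter) from compound 1 to compound 3 and a number 15.3 percentage points higher (beyond the scatter) from compound 2 to compound 4, 25.3 percentage points apart, beyond the scatter of two such steps. Across these two pairs, then, the step seen on one core could not be carried over to the other, either in size or in direction. This does not show whether the core or the place of the chloro sets the difference, as the chloro sits in a different place in each pair and the two cannot be told apart here, and two steps give no rule for any further core.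

The compounds shown leave open how chloro would read on the six-membered aromatic ring of carbon only in the core of compound 1. They also leave open whether another group on that carbon in the core of compound 2, such as methoxy or an amine, would follow chloro.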